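A few compounds are considered here, and "the series" means these few. Any claim that something is new, unique, unknown or untested is made for them only; others in the source may bear on it.

In a functional assay on SW-620 cells (Homo sapiens) for antiproliferative activity, read by MTT assay, with a stated time of 24 h (on this read-out higher numbers stand for weaker inhibition and lower numbers for stronger inhibition), compound 1 (`COc1ccc(C(=O)/C=C/c2ccc([N+](=O)[O-])cc2)c2c1C=CC(C)(C)O2`) gives 3520 nM. Compound 2 (`COc1ccc(C(=O)/C=C/c2cccs2)c2c1C=CC(C)(C)O2`) reads > 10000 nM, which is a limit of the assay and not a number. Compound 3 (`COc1ccc(C(=O)/C=C/c2ccc(Cl)c(Cl)c2)c2c1C=CC(C)(C)O2`) carries 3,4-dichlorophenyl in place of thiophen-2-yl on a double-bonded chain carbon bound to a double-bonded chain carbon. Within the data shown here, only one measured step bears on this, an at least 2.8-fold higher number from compound 1 to compound 2 (0.45 log units; beyond the scatter), where thiophen-2-yl replaced 4-nitrophenyl at the same place. The new change returns to a substituted phenyl ring, so a modest move towards a lower number is expected, an at least 2.0-fold lower number from compound 2 to compound 3 (0.30 log units; that floor lies within the scatter). Compound 3 is estimated at 5000 nM, with an expected range from 1500 nM to 15000 nM.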

Compound 3, half-maximal inhibitory concentration: 7700 nM
Compound 3: middle estimate off by 1.5-fold (0.19 log units), on the low side; low and high end bracket the measured number.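

At this place on the chain, two substituted phenyl rings can now be compared directly in this assay: going from 4-nitrophenyl to 3,4-dichlorophenyl gives a 2.2-fold higher number from compound 1 to compound 3 (0.34 log units; beyond the scatter), so the choice of substituents on the phenyl ring matters here. Compound 2 reads > 10000 nM, which is a limit of the assay and not a number. The step away from thiophen-2-yl is therefore only a floor, an at least 1.2-fold lower number from compound 2 to compound 3 (0.11 log units; that floor lies within the scatter), and its true size stays unknown: the limit of > 10000 nM in this assay, at which 1 of the 3 values shown sits.

The compounds shown leave open whether an unsubstituted phenyl ring, or a phenyl ring carrying an amine or a carboxylic acid, at this place would give a lower number than compound 1.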